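A few compounds are considered here, and "the series" means these few. Any claim that something is new, unique, unknown or untested is made for them only; others in the source may bear on it.

In a functional assay on A549 cells (Homo sapiens) for antiproliferative activity, read by MTT assay (on this read-out higher numbers stand for weaker inhibition and lower numbers for stronger inhibition), compound 1 `Cn1c(=O)c(=O)n(C2CCCC2)c2nc(N/N=C/c3ccc(O)cc3)ncc21`, with hydroxy on its aromatic ring, reports > 100000 nM, a limit of the assay. Compound 2 `Cn1c(=O)c(=O)n(C2CCCC2)c2nc(N/N=C/c3ccc(Cl)cc3)ncc21`, with chloro, gives 6890 nM. Compound 3 `Cn1c(=O)c(=O)n(C2CCCC2)c2nc(N/N=C/c3ccc(C(F)(F)F)cc3)ncc21`, with trifluoromethyl, gives 40600 nM, the higher of the two exact numbers. Replacing hydroxy produced an at least 14-fold lower number from compound 1 to compound 2 (1.16 log units; beyond the scatter) and an at least 2.4-fold lower number from compound 1 to compound 3 (0.39 log units; beyond the scatter), while a 5.9-fold higher number from compound 2 to compound 3 (0.77 log units; beyond the scatter) is modest. Compound 4 `COc1ccc(/C=N/Nc2ncc3c(n2)n(C2CCCC2)c(=O)c(=O)n3C)c(OC)c1` carries 2,4-dimethoxyphenyl in place of 4-(trifluoromethyl)phenyl on a carbon with a double bond to nitrogen. Among the measured compounds shown here, no measured step tests methoxy directly, but oxygen also sits on the ring of compound 1, and an at least 2.4-fold lower number from compound 1 to compound 3 (0.39 log units; beyond the scatter) gives no sign that oxygen helps. The expected change, a 1.1-fold higher number from compound 3 to compound 4 (0.04 log units; within the scatter), therefore stays within the scatter. For compound 4 the estimated value is 45000 nM, with an expected range of 12000 nM to 100000 nM.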

Compound 4, half-maximal inhibitory concentration: > 100000 nM
Compound 4 ended at the assay's limit; the forecaster's own chance of this, stated with the estimate: 25%; at least 2.2-fold (0.34 log units) between middle value and limit.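

Placing 2,4-dimethoxyphenyl on this carbon with a double bond to nitrogen gives an at least 2.4-fold higher number from compound 3 to compound 4 (0.39 log units; beyond the scatter) and an at least 14-fold higher number from compound 2 to compound 4 (1.16 log units; beyond the scatter), so this ring is clearly weaker than both 4-(trifluoromethyl)phenyl and 4-chlorophenyl. Among the four compounds, the two rings carrying oxygen, in compound 1 and compound 4, both end at a limit, whereas the two without oxygen give exact numbers. The step from compound 1 to compound 4 cannot be read, because both values are limits: the limit of > 100000 nM in this assay, at which 2 of the 4 values shown sit.

From the compounds shown here alone, whether oxygen itself or the presence of two ring groups matters remains open. A 4-methoxyphenyl or 4-aminophenyl ring could help separate these possibilities.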